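The source may report more compounds than this note shows. Statements on the series, on what has been measured and on what is new or still open speak of the compounds shown alone.

This account follows one change made to compound 1, whose structure is `O=S(=O)(Nc1nccs1)c1ccc2c(c1)OCC[C@@H]2c1ccc(C(F)(F)F)cc1N1CCNCC1`. It was tested in a physicochemical assay for lipophilicity (on this read-out higher numbers stand for higher lipophilicity and lower numbers for lower lipophilicity), and on that read-out compound 1 gives 1.4. A second compound, compound 2, with structure `O=S(=O)(Nc1ncccn1)c1ccc2c(c1)OCC[C@@H]2c1ccc(C(F)(F)F)cc1-c1ccc(F)cn1`, was measured the same way, and compound 2 gives 2.9. For the measured compounds named here, of the two numbers known so far, compound 1 stands as the lower one, with compound 2 sitting well beyond the scatter above it.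

The new compound is compound 3, with structure `O=S(=O)(Nc1nccs1)c1ccc2c(c1)OCC[C@@H]2c1ccc(C(F)(F)F)cc1-c1nccs1`. It differs from compound 1 in one place: 1,3-thiazol-2-yl in place of piperazin-1-yl on an aromatic carbon. The group that leaves carries one hydrogen-bond donor; the group that enters carries none.

Going by the values given here, no measured pair here shows this particular exchange, so the size of the step can only be expected, not read off. Compound 2, which also carries no piperazin-1-yl group, gives 2.9, and that suggests the direction. The step from compound 1 to compound 3 in this assay is expected to be upward by about a number 1.60 log units higher from compound 1 to compound 3 (beyond the scatter), beyond the scatter. Compound 3 is therefore estimated at 3, within a range from 2.3 to 3.7.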

Compound 3, distribution coefficient: 3.3
Compound 3: middle estimate off by 0.30 log units, on the low side, and the stated range covers the measured number.
By their numbers in this assay, from the lowest: compound 1; then compound 2; then compound 3.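

In this assay, for the compounds shown here, placing 1,3-thiazol-2-yl where compound 1 carries piperazin-1-yl gives a number 1.90 log units higher from compound 1 to compound 3 (beyond the scatter), the first step at this position that can be read from two compounds differing in one place only. It shows that this aromatic carbon, ortho to a large group and meta to a trifluoromethyl group, is a place where a single exchange of groups can move this read-out by a large amount while the shared core stays the same. No measurement shown here explains why the step has this size.

Several things change together in this one exchange: a six-membered non-aromatic ring gives way to a five-membered aromatic ring, and the group that enters has no hydrogen-bond donor, so this pair cannot show which difference matters for the step. On these data alone, a morpholin-4-yl group or a phenyl ring at the same carbon could help separate these differences, and it remains open whether the same exchange would give a similar step on a compound with a different group on the sulfonamide nitrogen.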